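Fluorophenyl for methylphenyl on the two-carbon thioether chain

This account rests on a few compounds, and the source may have more. Where it says the series, first, only, none or still open, it means among the compounds named here.

Compound 2 `C#CCNC1CCc2c(SCCc3ccc(C)cc3)cccc21` gives 4520 nM in an ADME assay on isolated protein for inhibition of Amine oxidase [flavin-containing] B (Homo sapiens) (a lower number here means a stronger inhibitor, a higher number a weaker inhibitor), the highest of the three numbers: compound 1 `C#CCNC1CCc2c(SCc3ccc(Br)cc3)cccc21` gives 488 nM and compound 3 `C#CCNC1CCc2c(SCc3ccc(C(F)(F)F)cc3)cccc21` gives 930 nM, both beyond the scatter away from compound 2. Compound 4 `C#CCNC1CCc2c(SCCc3cccc(F)c3)cccc21` carries 3-fluorophenyl in place of 4-methylphenyl on a saturated chain carbon, two bonds along the chain from a sulfur. Within the data shown here, the only measured step that touches an aromatic substituent is a 1.9-fold higher number from compound 1 to compound 3 (0.28 log units; within the scatter), within the scatter, and it sits on a one-carbon linker rather than the chain of compound 2, so it bears only loosely. Among the measured compounds shown here, no measured pair swaps a 4-methyl for a 3-fluoro on the two-carbon chain. Compound 4 is therefore expected near compound 2, with a step of a 1.3-fold lower number from compound 2 to compound 4 (0.11 log units; within the scatter) that need not exceed the scatter. The estimate for compound 4 is 3500 nM, within 1200 nM to 10000 nM.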

Compound 4, half-maximal inhibitory concentration: 7810 nM
The estimate for compound 4 lay 2.2-fold (0.35 log units) below the measured number; the measured number falls inside the stated range.
By their numbers in this assay, from the lowest: compounds 1 and 3 (each within the scatter of the next); then compounds 2 and 4 (each within the scatter of the next).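

In this assay, 3-fluorophenyl in place of 4-methylphenyl on a saturated chain carbon, two bonds along the chain from a sulfur, gives a 1.7-fold higher number from compound 2 to compound 4 (0.24 log units; within the scatter) and so stays within the scatter. On this two-carbon chain, the two aryl groups cannot be told apart in this assay, although this single swap alters both the substituent and where it sits on the phenyl ring. No supporting data bear on this result.

As far as these compounds go, whether an amine or a carboxylic acid on that phenyl ring would give a step beyond the scatter remains open. So does the reading for a longer chain carrying 3-fluorophenyl.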